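Aryl and carboxy variation on the shared core

The source may report more compounds than this note shows. Statements on the series, on what has been measured and on what is new or still open speak of the compounds shown alone.

Compound 3 `CCCCCCCCc1ccc(OCC(=O)Cn2nnc(C(=O)O)n2)cc1` gives 41 nM in an assay on microsomes from brain for inhibition of Fatty-acid amide hydrolase 1 (Rattus norvegicus), read by fluorescence and HPLC, with a stated time of 60 min; a higher number here means a weaker inhibitor, a lower number a stronger inhibitor. Compound 1 `CCCCCCCCc1ccc(OCC(=O)Cn2nnc(-c3ccccc3Cl)n2)cc1` gives 32 nM in this assay, and compound 2 `CCCCCCCCc1ccc(OCC(=O)Cn2nnc(-c3cccc(C(=O)OC)c3)n2)cc1` gives 34 nM. The three numbers lie close together: a 1.3-fold higher number from compound 1 to compound 3 (0.11 log units; within the scatter), a 1.2-fold higher number from compound 2 to compound 3 (0.08 log units; within the scatter) and a 1.1-fold higher number from compound 1 to compound 2 (0.03 log units; within the scatter), each within the scatter. On these numbers compound 3 stands nowhere apart from the other two; whatever sits on the aromatic carbon of the shared core, whether 2-chlorophenyl, 3-(methoxycarbonyl)phenyl or carboxy, the read-out has so far been indistinguishable.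

Compound 4 `CCCCCCCCc1ccc(OCC(=O)Cn2nnc(-c3ccc(C(=O)O)cc3)n2)cc1` is not yet measured. The change from compound 3: 4-carboxyphenyl in place of carboxy on an aromatic carbon. Within the data shown here, the steps that bear on it are the two runs in the opposite direction, an aryl group replaced by carboxy, and both fell within the scatter, as noted above. A phenyl carrying a carboxy in place of a bare carboxy is therefore expected to give no step beyond the scatter in this assay; for compound 4 the expected step is a 1.2-fold lower number from compound 3 to compound 4 (0.07 log units; within the scatter). Compound 4 is estimated at 35 nM, with a range from 15 nM to 80 nM.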

Compound 4, half-maximal inhibitory concentration: 90 nM
Compound 4: the middle estimate sits 2.6-fold (0.41 log units) below what was measured, and the stated range ends below it.
By their numbers in this assay, from the lowest: compounds 1, 2 and 3 (each within the scatter of the next); then compound 4.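

In this assay this position, on an aromatic carbon of a five-membered aromatic ring with 4 nitrogen, shows its first steps beyond the scatter: a 2.2-fold higher number from compound 3 to compound 4 (0.34 log units; beyond the scatter) and a 2.6-fold higher number from compound 2 to compound 4 (0.42 log units; beyond the scatter) and a 2.8-fold higher number from compound 1 to compound 4 (0.45 log units; beyond the scatter) all separate 4-carboxyphenyl from the other three groups. The position is therefore not indifferent to what it carries, and neither carboxy on its own in compound 3 nor an aryl group with another substituent in compound 1 and compound 2 gives such a step; only compound 4 combines a phenyl with a carboxy. No measurement available here accounts for this step.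

Open, from the compounds shown here alone, is how an unsubstituted phenyl or a phenyl carrying an amine would stand against compound 4, and so whether the carboxy on the ring matters to the step. Going by these compounds, all four compounds carry the same octyl chain, so whether the step persists with a shorter chain also remains open.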